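The compounds below may be only part of what the source reports. "The series", "measured", "known", "first", "only" and "open" are said of these compounds alone.

Compound 1 `Nc1ccccc1NC(=O)/C=C/c1ccc(Cn2cnc3c(Nc4ccccc4)nc(Cl)nc32)cc1`: 7.75%
Compound 2 `Nc1ccccc1NC(=O)c1ccc(Cn2cnc3c(Nc4ccc(-c5ccccn5)cc4)nc(Cl)nc32)cc1`: 69.5%
Compound 3 `CC1CCN(c2nc(Cl)nc3c2ncn3Cc2ccc(/C=C/C(=O)Nc3ccccc3N)cc2)CC1`: 4.24%

In a functional assay on HCT-116 cells (Homo sapiens) for antiproliferative activity, read by CCK-8 assay, with a stated time of 72 h, tested at 2 uM (a lower number here means a weaker effect, a higher number a stronger effect of the compound at the concentration tested), compound 2 stands highest of the three numbers; compound 1 lies far lower, beyond the scatter, and compound 3 lower still, also beyond the scatter. Compound 4 `Nc1ccccc1NC(=O)c1ccc(Cn2cnc3c(Nc4cccc(Cl)c4)nc(Cl)nc32)cc1` has not yet been measured. It differs from compound 2 in one place: 3-chlorophenyl in place of 4-(pyridin-2-yl)phenyl on a nitrogen on an aromatic ring.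

Going by the values given here, only one measured step is known, a number 3.5 percentage points lower from compound 1 to compound 3 (within the scatter), and it exchanges the whole group on the aromatic carbon rather than a substituent on the anilino ring, so it does not bear directly on the present change. Compound 1 carries a plain anilino but also a different amide linker, so its low value cannot be assigned to the aryl group alone. Since compound 2, which carries the 4-(pyridin-2-yl)phenyl, stands so far above the other two, the change to 3-chlorophenyl is expected to lower the number, by a number 34.5 percentage points lower from compound 2 to compound 4 (beyond the scatter), with wide uncertainty. Compound 4 is therefore estimated at 35%, within 8% to 65%.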

Compound 4, a percentage reported as inhibition, at one concentration (the size of the read-out at that concentration, not a potency): 56.2%
Compound 4: the middle estimate sits 21.2 percentage points below what was measured, and the stated range covers the measured number.
By their numbers in this assay, from the lowest: compounds 3 and 1 (each within the scatter of the next); then compound 4; then compound 2.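

In this assay, placing 3-chlorophenyl on this nitrogen instead of 4-(pyridin-2-yl)phenyl gives a number 13.3 percentage points lower from compound 2 to compound 4 (beyond the scatter). The change removes one of the two aromatic rings and the ring nitrogen, yet compound 4 still gives 56.2%, so at this position, with this amide, the larger 4-(pyridin-2-yl)phenyl group is not needed for a sizeable read-out at the concentration tested. No evidence is available to explain the size of this step.

The compounds shown leave open how much of the remaining effect depends on the chlorine, and whether the same number would be seen with a plain phenyl, a methoxy-substituted phenyl or a 4-pyridyl group on this nitrogen. They also do not show whether a saturated amine such as morpholine could take the place of the anilino group when this amide is kept.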